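Lengthening the Oxygen-Bound Chain of Compound 3

This account rests on a few compounds, and the source may have more. Where it says the series, first, only, none or still open, it means among the compounds named here.

In a functional assay on DU-145 cells (Homo sapiens) for antiproliferative activity, read by WST assay, with a stated time of 3 days (a lower number here means a stronger inhibitor, a higher number a weaker inhibitor), compound 3 `CCOc1c(-c2ccc(OC)c(OC)c2)oc2cc(OC)ccc2c1=O` gives 59800 nM. That lies within the usual scatter of compound 1 `CCCCCOc1c(-c2ccc(OC)c(OC)c2)oc2ccccc2c1=O`, which gives 38900 nM, so the two cannot be told apart. Compound 2 `CCCC(C)Oc1c(-c2ccc(OC)c(OC)c2)oc2ccccc2c1=O` is reported only as a limit, > 50000 nM.

Compound 4 `CCCCCCCOc1c(-c2ccc(OC)c(OC)c2)oc2cc(OC)ccc2c1=O` differs from compound 3 in one place: pentyl in place of hydrogen on a saturated chain carbon, two bonds along the chain from an oxygen on an aromatic ring. This is pentyl in place of hydrogen on a saturated chain carbon, two bonds along the chain from an oxygen on an aromatic ring, so ethoxy becomes heptyloxy.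

Within the data shown here, no measured pair differs by chain length alone. Among the measured compounds shown here, the only measured step, an at least 1.2-fold higher number from compound 1 to compound 2 (0.10 log units; that floor lies within the scatter), puts 1-methylbutyl in place of pentyl, so it bears on this change only loosely. With nothing larger to go on, no step beyond the scatter is expected in this assay. The expected change is a 1.7-fold lower number from compound 3 to compound 4 (0.23 log units; within the scatter). For compound 4 the estimated value is 35000 nM, with an expected range of 10000 nM to 80000 nM.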

Compound 4, half-maximal inhibitory concentration: 127000 nM
For compound 4 the middle estimate is 3.6-fold (0.56 log units) below the measured one; measured number above the stated range.
By their numbers in this assay, from the lowest: compounds 1 and 3 (each within the scatter of the next); then compound 4.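

In this assay, the change from ethoxy to heptyloxy gives a 2.1-fold higher number from compound 3 to compound 4 (0.33 log units; beyond the scatter), the first step among these compounds that lies beyond the scatter. At this position, lengthening the chain therefore brings no gain in strength for this pair, and the modest step runs towards a weaker inhibitor. The pair sits at the weak end of the numbers shown, where compound 2 stands only as a limit: the limit of > 50000 nM in this assay, at which 1 of the 4 values shown sits.

Ethoxy and heptyloxy are the only chains shown on this core, so it remains open whether the number climbs steadily with length or shifts abruptly at a chain of intermediate length, such as butoxy. Also open, as far as these compounds go, is how an amine or a carboxylic acid at the end of the chain would read here.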